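The source may report more compounds than this note shows. Statements on the series, on what has been measured and on what is new or still open speak of the compounds shown alone.

Within the data shown here, in a physicochemical assay for lipophilicity, read by HPLC, with a stated time of 90 min, tested at 100 uM (on this read-out higher numbers stand for higher lipophilicity and lower numbers for lower lipophilicity), compound 1 `O=C(Nc1ccc(C(F)(F)F)cc1)NC1CCN(C(=O)C2CCCOC2)CC1` gives 3.41, the lowest number of the three measured so far. Compound 3 `O=C(Nc1ccc(OC(F)(F)F)c(F)c1)NC1CCN(C(=O)C2CC2)CC1` reads 4.19 and compound 2 `O=C(Nc1ccc(OC(F)(F)F)c(F)c1)NC1CCN(C(=O)C2(C(F)(F)F)CC2)CC1` reads 5.94, both beyond the scatter above compound 1. Compound 4 `Cc1ccoc1C(=O)N1CCC(NC(=O)Nc2ccc(C(F)(F)F)cc2)CC1` departs from compound 1 with 3-methylfuran-2-yl in place of oxan-3-yl on a carbonyl carbon. Among the measured compounds shown here, the only measured step, a number 1.75 log units lower from compound 2 to compound 3 (beyond the scatter), is large but concerns hydrogen in place of trifluoromethyl on a saturated ring carbon, so it bears only loosely on this change. A moderate rise, smaller than that step, is expected, and the estimated step is a number 0.69 log units higher from compound 1 to compound 4 (beyond the scatter). The estimated value for compound 4 is 4.1, with an expected range of 3.6 to 4.6.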

Compound 4, partition coefficient: 4.29
Compound 4: the middle estimate sits 0.19 log units below what was measured; the range from low to high includes it.
By their numbers in this assay, from the lowest: compound 1; then compounds 3 and 4 (each within the scatter of the next); then compound 2.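

In this assay the exchange of oxan-3-yl for 3-methylfuran-2-yl on a carbonyl carbon gives a number 0.88 log units higher from compound 1 to compound 4 (beyond the scatter) as the first step read at this position on the core of compound 1. Both groups hold 6 heavy atoms, 0 hydrogen-bond donors and 1 hydrogen-bond acceptor, so the step comes with no change in these counts, while the ring goes from six-membered non-aromatic to five-membered aromatic. No measured evidence accounts for the step.
Open, as far as these compounds go, is how much of the step belongs to the methyl, which furan-2-yl would test, and how an amine or a carboxylic acid would read on this carbonyl carbon.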